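The source may report more compounds than this note shows. Statements on the series, on what has been measured and on what is new or still open speak of the compounds shown alone.

Among the compounds with values here, compound 1 `O=C(CCCCCCc1ccccc1)c1ncc(-c2ccc(O)cc2)o1` is one of two compounds measured in an assay (Rattus norvegicus) for inhibition of Fatty-acid amide hydrolase 1 (Homo sapiens) (a lower number here means a stronger inhibitor, a higher number a weaker inhibitor), and compound 1 gives 140 nM. The other, compound 2 `O=C(CCCCCCc1ccccc1)c1ncc(-c2ccc(C(=O)C(F)(F)F)cc2)o1`, carries a (trifluoromethyl)carbonyl in place of the hydroxy on its aromatic carbon, and in this assay compound 2 gives 65 nM. Within the data shown here, of the two numbers, compound 1 stands highest; the only step known is a 2.2-fold lower number from compound 1 to compound 2 (0.33 log units; beyond the scatter), a modest improvement.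

Compound 3 `CN(C)C(=O)c1cnc(C(=O)CCCCCCc2ccccc2)o1` differs from compound 1 at a different place: dimethylcarbamoyl in place of 4-hydroxyphenyl on an aromatic carbon. Here the whole aromatic ring and its hydroxy leave the shared core, and a small group without a ring enters in its stead. Among the measured compounds shown here, none of the measured steps covers this kind of change; the step from compound 1 to compound 2 swaps only a group on the ring and says nothing about removing the ring itself. With no guide from the measured pair, a loss of the ring is expected to cost some binding, so a modest weakening is estimated, a 2.1-fold higher number from compound 1 to compound 3 (0.33 log units; beyond the scatter). Compound 3 is therefore expected to give about 300 nM in this assay, with a likely range from 80 nM to 1200 nM.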

Compound 3, inhibition constant: 2 nM
Beside the measured number, compound 3's estimate is 150-fold (2.18 log units) above it, outside the stated range (below it).
By their numbers in this assay, from the lowest: compound 3; then compound 2; then compound 1.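

The place next to the ring oxygen turns out not to need the 4-hydroxyphenyl group: with dimethylcarbamoyl there, this assay shows a 70-fold lower number from compound 1 to compound 3 (1.85 log units; beyond the scatter) in a single change. An aromatic ring at this place is therefore not required for a low number, and a group with no ring and no hydrogen-bond donor can take its place with a large gain. This step is also much larger than a 2.2-fold lower number from compound 1 to compound 2 (0.33 log units; beyond the scatter), which only exchanged a group on the ring, so replacing the whole 4-hydroxyphenyl group moved the number far more than that exchange did, and nothing available here accounts for the size of the change.

The compounds shown leave open which part of dimethylcarbamoyl matters, since a primary carboxamide, a carboxylic acid, a methyl ester or a nitrile at the same place would separate the carbonyl from the two methyl groups on the nitrogen. They also leave open whether the gain holds with a shorter chain in place of the phenyl-ended chain on the ketone, or with a small ring such as a morpholine amide on the same carbonyl.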